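Working notes: phenyl to butyl in a cytotoxicity series

A few compounds are considered here, and "the series" means these few. Any claim that something is new, unique, unknown or untested is made for them only; others in the source may bear on it.

Measured in a functional assay on HeLa cells (Homo sapiens) for cytotoxicity, read by MTT assay; on this read-out higher numbers stand for weaker inhibition and lower numbers for stronger inhibition:
compound 1 `CCCCC(O)CC(=O)O[C@H](CC=C(C)C)C1=CC(=O)c2c(O)ccc(O)c2C1=O` gives 72200 nM
compound 2 `CC(C)=CC[C@@H](OC(=O)CC(O)c1ccccc1)C1=CC(=O)c2c(O)ccc(O)c2C1=O` gives 44500 nM
compound 3 `CC(C)=CC[C@@H](OC(=O)CC(C)(O)c1ccccc1)C1=CC(=O)c2c(O)ccc(O)c2C1=O` gives 85700 nM

Compound 3 differs from compound 2 by methyl in place of hydrogen on a saturated chain carbon bound to an aromatic carbon, an oxygen on a saturated carbon and a saturated chain carbon; the step is a 1.9-fold higher number from compound 2 to compound 3 (0.28 log units; within the scatter). Compound 1 differs from compound 2 by butyl in place of phenyl on a saturated chain carbon bound to an oxygen on a saturated carbon and a saturated chain carbon; this change made the step of a 1.6-fold higher number from compound 2 to compound 1 (0.21 log units; within the scatter). Between compound 1 and compound 3 the step is a 1.2-fold higher number from compound 1 to compound 3 (0.07 log units; within the scatter).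

Compound 4 `CCCCC(C)(O)CC(=O)O[C@H](CC=C(C)C)C1=CC(=O)c2c(O)ccc(O)c2C1=O` is not yet measured. It differs from compound 3 by butyl in place of phenyl on a saturated chain carbon bound to an oxygen on a saturated carbon and two saturated chain carbons. Going by the values given here, this is the same kind of change as the one leading to compound 1, but the place is not the same word for word: in the earlier pair the carbon is bound to an oxygen on a saturated carbon and a saturated chain carbon, here to an oxygen on a saturated carbon and two saturated chain carbons. The change occurs twice among the compounds shown. Among the compounds with values here, the expected step in this assay is a 1.4-fold higher number from compound 3 to compound 4 (0.15 log units; within the scatter), set beside the earlier 1.6-fold higher number from compound 2 to compound 1 (0.21 log units; within the scatter), the only other instance of the change, which lay within the scatter. Compound 4 is estimated at 120000 nM, with a range from 50000 nM to 300000 nM.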

Compound 4, half-maximal inhibitory concentration: 60600 nM
Estimate against measurement, compound 4: 2.0-fold (0.30 log units) above, and the stated range covers the measured number.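

Butyl in place of phenyl on the core bearing the extra methyl gives a 1.4-fold lower number from compound 3 to compound 4 (0.15 log units; within the scatter) in this assay, and this step does not differ from the earlier instance of the same change: the same change on two cores in this assay, a 1.6-fold higher number (0.21 log units; within the scatter) from compound 2 to compound 1 and a 1.4-fold lower number (0.15 log units; within the scatter) from compound 3 to compound 4, 2.3-fold (0.36 log units) apart, within the scatter of two such steps. Methyl in place of hydrogen gives a 1.2-fold lower number from compound 1 to compound 4 (0.08 log units; within the scatter), which likewise does not differ from its earlier instance: the same change on two cores in this assay, a 1.9-fold higher number (0.28 log units; within the scatter) from compound 2 to compound 3 and a 1.2-fold lower number (0.08 log units; within the scatter) from compound 1 to compound 4, 2.3-fold (0.36 log units) apart, within the scatter of two such steps. The remaining step, a 1.4-fold higher number from compound 2 to compound 4 (0.13 log units; within the scatter), also lies within the scatter, so the series shows that neither change produces a step beyond the scatter on either core, but it does not show that either change carries a fixed size or direction from one core to another.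

On these data alone, with all four compounds within the scatter of one another, it remains open which groups at this place, if any, would give a step beyond the scatter. An amine or a carboxylic acid in place of the butyl or phenyl, or a longer chain than butyl, would test this.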